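A few compounds are considered here, and "the series" means these few. Any claim that something is new, unique, unknown or untested is made for them only; others in the source may bear on it.

Three small compounds share a ring carrying an acetyl or a cinnamoyl group. In a functional assay on HCT-116 cells (Homo sapiens) for cytotoxicity, read by resazurin assay, with a stated time of 72 h (on this read-out lower numbers stand for stronger inhibition and higher numbers for weaker inhibition), compound 1 `COc1cc(OC)c(C(C)=O)c(OC)c1` gives only a limit, > 20000 nM. Compound 2 `COCOc1cc(OC)cc(OC)c1C(C)=O` also gives only a limit in this assay, > 20000 nM. Compound 3 `COCOc1cc(OCOC)c(C(=O)/C=C/c2ccccc2)c(OCOC)c1` likewise stays at a limit in this assay, > 20000 nM. How the core of compound 3 differs from that of compound 2 is not broken down here. The change from compound 2 to compound 1 is hydrogen in place of methoxy on a saturated chain carbon bound to an oxygen on an aromatic ring, and a step that the two limits leave unreadable from compound 2 to compound 1, because of the limit of > 20000 nM in this assay, at which 3 of the 3 values shown sit. Compound 4 `COCOc1cc(OC)c(C(=O)/C=C/c2ccccc2)c(OCOC)c1` arises from compound 3 by the same change, (hydrogen in place of methoxy on a saturated chain carbon bound to an oxygen on an aromatic ring). With both ends of the measured step sitting at the limit, the expected step in this assay is a step that the limit leaves unreadable from compound 3 to compound 4, resting on compound 3 at > 20000 nM. Compound 4 is therefore estimated at 25000 nM.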

Compound 4, half-maximal inhibitory concentration: > 20000 nM
Compound 4: a limit, no number (the forecaster's own chance of this, stated with the estimate: 70%); the middle value lies beyond the limit too.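

No step can be read between compound 3 and compound 4, because both stay at a limit: the limit of > 20000 nM in this assay, at which 4 of the 4 values shown sit.

Whether replacing methoxymethoxy with methoxy changes activity at all in this assay remains open, as does how active any of these compounds is.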